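This account rests on a few compounds, and the source may have more. Where it says the series, first, only, none or still open, it means among the compounds named here.

Compound 1 `O=C(Nc1ccc(Oc2ccnc3[nH]ccc23)cc1)c1cn(-c2ccc(Br)cc2)c2ccccc2c1=O` is the anchor of this small series. In a functional assay on HepG2 cells (Homo sapiens) for inhibition, read by MTT assay, with a stated time of 72 h (a higher number here means a weaker inhibitor, a lower number a stronger inhibitor), compound 1 gives 220 nM. Within the data shown here, compound 2 `O=C(Nc1ccc(Oc2ccnc3[nH]ccc23)cc1)c1cn(-c2ccc(Br)cc2F)c2ccccc2c1=O` carries a fluoro in place of hydrogen on an aromatic carbon, and in this assay compound 2 gives 790 nM; the step of a 3.6-fold higher number from compound 1 to compound 2 (0.56 log units; beyond the scatter) is the only measured comparison within one change. Compound 3 `O=C(Nc1ccc(Oc2ccnc3[nH]ccc23)cc1)c1cn(-c2ccc(C(F)(F)F)cc2Cl)c2ccccc2c1=O` stands apart: in this assay compound 3 gives "not determined" (no result reported), so there is no number from which to measure the next step directly.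

Compound 4 `COc1ccc(-n2cc(C(=O)Nc3ccc(Oc4ccnc5[nH]ccc45)cc3)c(=O)c3ccccc32)cc1` is related to compound 3 by 4-methoxyphenyl in place of 2-chloro-4-(trifluoromethyl)phenyl on an aromatic nitrogen. Among the measured compounds shown here, no measured step covers this exchange, so the expectation leans on the compounds that share the same core. Compound 1, with a 4-bromophenyl on that nitrogen, sits at 220 nM, while compound 2 shows that adding a fluoro on that ring moved the number beyond the scatter in the weaker direction. For the measured compounds named here, compound 4 carries a single group on that ring, as compound 1 does, and is therefore expected to land near compound 1 rather than near compound 2, with no large step predicted in either direction. On that basis compound 4 is estimated at 300 nM in this assay, with a plausible range from 100 nM to 1000 nM.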

Compound 4, half-maximal inhibitory concentration: 5950 nM
Compound 4: middle estimate off by 20-fold (1.30 log units), on the low side; the measured number lies above the stated range.
By their numbers in this assay, from the lowest: compound 1; then compound 2; then compound 4.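

On the aryl ring carried by the aromatic nitrogen, the exchange of bromo for methoxy gives a 27-fold higher number from compound 1 to compound 4 (1.43 log units; beyond the scatter) in this assay, so two compounds that each carry a single group on that ring can lie far apart. This step is printed as large, whereas the addition of fluoro to compound 1 gave the modest 3.6-fold higher number from compound 1 to compound 2 (0.56 log units; beyond the scatter), and the change from 4-bromo-2-fluorophenyl to 4-methoxyphenyl still gives a 7.5-fold higher number from compound 2 to compound 4 (0.88 log units; beyond the scatter). Among these compounds, the identity of the single group on this ring therefore matters more than the earlier pair could show, but nothing available here explains the size of these steps.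

The compounds shown leave open where a chloro, a methyl or an amino group in place of the bromo would fall relative to compound 1 and compound 4. Steps to compound 3 cannot be read, and the standing of its 2-chloro-4-(trifluoromethyl)phenyl group in this assay remains open as well.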